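The source may hold more compounds than are shown below. What is called first, only, known or untested is meant among the compounds shown, and "the series" means these compounds.

Measured so far:
Compound 1 `CNC(=O)c1cc(Oc2ccc(C(=O)/C=C/c3ccc(Br)cc3)cc2)ccn1`: > 50000 nM
Compound 2 `CNC(=O)c1cc(Oc2ccc(C(=O)/C=C/c3ccc([N+](=O)[O-])cc3)cc2)ccn1`: "not determined" (no result reported)
Compound 3 `CNC(=O)c1cc(Oc2ccc(C(=O)/C=C/c3ccc(OC)cc3)cc2)ccn1`: "not determined" (no result reported)

In a functional assay on HepG2 cells (Homo sapiens) for cytotoxicity, read by MTT assay, with a stated time of 72 h (a lower number here means a stronger inhibitor, a higher number a weaker inhibitor), compound 1 gives > 50000 nM, which is a limit of the assay and not a number. Its standing is therefore summed up as the limit of > 50000 nM in this assay, at which 1 of the 3 values shown sits. Among the measured compounds shown here, compound 2 and compound 3 have no reported result, so the series offers no measured step to scale a change.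

Next in line is compound 4 `CNC(=O)c1cc(Oc2ccc(C(=O)/C=C/c3ccc(Cl)cc3Cl)cc2)ccn1`, which carries 2,4-dichlorophenyl in place of 4-bromophenyl on a double-bonded chain carbon bound to a double-bonded chain carbon. The only anchor in this assay is compound 1 at > 50000 nM, again a limit. A result at the same limit is quite possible, and any number that does appear is expected to lie not far from it. The expected change is a small one towards stronger inhibition, estimated as an at least 1.2-fold lower number from compound 1 to compound 4 (0.09 log units; that floor lies within the scatter). For compound 4 the estimate is 40000 nM, with an expected range of 15000 nM to 100000 nM.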

Compound 4, half-maximal inhibitory concentration: 11700 nM
For compound 4 the middle estimate is 3.4-fold (0.53 log units) above the measured one; measured number below the stated range.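

In this assay, among the compounds shown here, the place on a double-bonded chain carbon bound to a double-bonded chain carbon proves able to shift the read-out: 2,4-dichlorophenyl in place of 4-bromophenyl gives an at least 4.2-fold lower number from compound 1 to compound 4 (0.63 log units; beyond the scatter), and compound 4 supplies the first single number, 11700 nM. Compound 1 stands at > 50000 nM, which is a limit of the assay and not a number. The step is therefore a floor, and its full size cannot be read: the limit of > 50000 nM in this assay, at which 1 of the 4 values shown sits.

This single step does not separate the change of halogen from the change in the number and placing of halogens on the ring. Also open, as far as these compounds go, is how the number responds at this place to an amine, a carboxylic acid or a longer chain.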